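A Recurring Swap Carried Over to a Second Core

The compounds below may be only part of what the source reports. "The series", "measured", "known", "first", "only" and "open" are said of these compounds alone.

Measured so far in an assay on HEK293 cells for displacement of a labelled ligand from NPC1-like intracellular cholesterol transporter 1 (Homo sapiens); a higher number here means a weaker inhibitor, a lower number a stronger inhibitor:
Compound 1 `CC(C)(C)c1ccc(C(=O)N2CCC3(CC2)C(=O)N(CC(=O)N2CCN(S(C)(=O)=O)CC2)CN3c2ccccc2)cc1` gives 19000 nM.
Compound 2 `CS(=O)(=O)N1CCN(C(=O)CN2CN(c3ccccc3)C3(CCN(C(=O)c4ccc(C5CCCCC5)cc4)CC3)C2=O)CC1` gives 6300 nM.
Compound 3 `CCOC(=O)C1CCCN(C(=O)CN2CN(c3ccccc3)C3(CCN(C(=O)c4ccc(C(C)(C)C)cc4)CC3)C2=O)C1` gives 8200 nM.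

Compound 1 and compound 2 differ in one place, (cyclohexyl in place of tert-butyl on an aromatic carbon), and that change produced a 3.0-fold lower number from compound 1 to compound 2 (0.48 log units; beyond the scatter). The cores of compound 1 and compound 3 differ by 3-(ethoxycarbonyl)piperidin-1-yl in place of 4-(methylsulfonyl)piperazin-1-yl on a carbonyl carbon, a difference that gave a 2.3-fold lower number from compound 1 to compound 3 (0.36 log units; beyond the scatter).

Compound 4 `CCOC(=O)C1CCCN(C(=O)CN2CN(c3ccccc3)C3(CCN(C(=O)c4ccc(C5CCCCC5)cc4)CC3)C2=O)C1` is not yet measured. It differs from compound 3 by cyclohexyl in place of tert-butyl on an aromatic carbon, the same change seen between compound 1 and compound 2, at a place described in the same words for both pairs. Because that earlier change gave a 3.0-fold lower number from compound 1 to compound 2 (0.48 log units; beyond the scatter), a step of similar size, a 3.0-fold lower number from compound 3 to compound 4 (0.48 log units; beyond the scatter), is expected from compound 3 to compound 4 in this assay, though it rests on a single prior pair on a different core. Compound 4 is therefore estimated at 2700 nM, expected to fall between 1200 nM and 6500 nM.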

Compound 4, half-maximal inhibitory concentration: 4200 nM
For compound 4 the middle estimate is 1.6-fold (0.19 log units) below the measured one; low and high end bracket the measured number.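

In this assay, cyclohexyl in place of tert-butyl on the second core gave a 2.0-fold lower number from compound 3 to compound 4 (0.29 log units; within the scatter), which matches the earlier step on the first core: the same change on two cores in this assay, a 3.0-fold lower number (0.48 log units; beyond the scatter) from compound 1 to compound 2 and a 2.0-fold lower number (0.29 log units; within the scatter) from compound 3 to compound 4, 1.5-fold (0.19 log units) apart, within the scatter of two such steps. The other swap, 3-(ethoxycarbonyl)piperidin-1-yl in place of 4-(methylsulfonyl)piperazin-1-yl, gave a 1.5-fold lower number from compound 2 to compound 4 (0.18 log units; within the scatter), and it also matches its earlier step: the same change on two cores in this assay, a 2.3-fold lower number (0.36 log units; beyond the scatter) from compound 1 to compound 3 and a 1.5-fold lower number (0.18 log units; within the scatter) from compound 2 to compound 4, 1.5-fold (0.19 log units) apart, within the scatter of two such steps. Both changes therefore carried over between these two cores without a detectable difference in step size, but four compounds cannot show that this holds on any other core, and neither new step is by itself beyond the scatter.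

The compounds shown leave open how other groups would behave at these two places, such as a phenyl ring in place of cyclohexyl or a carboxylic acid in place of the ethoxycarbonyl group.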